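Cyclopropyl on the amide nitrogen of compound 3

A few compounds are considered here, and "the series" means these few. Any claim that something is new, unique, unknown or untested is made for them only; others in the source may bear on it.

Three amides on a shared core have been measured in a functional assay on the whole organism with Mus musculus as the target, in the rotarod test; a higher number here means that more compound is needed for the effect, a lower number that less compound is needed. Compound 1 (`CCN(C)C(=O)/C=C1\CCc2c(F)cc(F)cc21`) gives 73 mg/kg, compound 2 (`CN(C)C(=O)/C=C1\CCc2c(F)cc(F)cc21`) gives 100 mg/kg and compound 3 (`NC(=O)/C=C1\CCc2c(F)cc(F)cc21`) gives 138 mg/kg. Compound 3 therefore stands within the scatter of both others, with a 1.4-fold higher number from compound 2 to compound 3 (0.14 log units; within the scatter) and a 1.9-fold higher number from compound 1 to compound 3 (0.28 log units; within the scatter).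

Compound 4 (`O=C(/C=C1\CCc2c(F)cc(F)cc21)NC1CC1`) follows from compound 3 by cyclopropyl in place of hydrogen on an amide-type nitrogen; in words, cyclopropyl in place of hydrogen on an amide-type nitrogen.

The two steps at this nitrogen are those just given, read backwards, since each swaps carbon groups for hydrogen. The remaining step, a 1.4-fold higher number from compound 1 to compound 2 (0.14 log units; within the scatter), changes only a chain on the same nitrogen and bears on it less directly. Within the data shown here, no measured compound carries cyclopropyl, and none keeps the amide hydrogen alongside a single carbon group, so the transfer is loose. All three steps lie within the scatter, so no step beyond the scatter is expected in this assay. At most, a slight lean towards a lower number is expected. The estimated step is a 1.3-fold lower number from compound 3 to compound 4 (0.12 log units; within the scatter). The estimate for compound 4 is 105 mg/kg, with an expected range from 60 mg/kg to 180 mg/kg.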

Compound 4, dose for half-maximal effect: 62 mg/kg
Compound 4: middle estimate off by 1.7-fold (0.23 log units), on the high side; measured number inside the range.
By their numbers in this assay, from the lowest: compounds 4, 1, 2 and 3 (each within the scatter of the next, the first and the last beyond it).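

In this assay, among these compounds, cyclopropyl on the amide-type nitrogen gives the first step beyond the scatter (a 2.2-fold lower number from compound 3 to compound 4 (0.35 log units; beyond the scatter)), and it does so with a single carbon group while the amide hydrogen stays in place, a pattern that none of the earlier compounds carried. Against the two amides with two carbon groups on this nitrogen, no such separation appears (a 1.6-fold lower number from compound 2 to compound 4 (0.21 log units; within the scatter); a 1.2-fold lower number from compound 1 to compound 4 (0.07 log units; within the scatter)), so cyclopropylamino on the carbonyl carbon stands apart only from amino and cannot be told from dimethylamino or ethyl(methyl)amino. Nothing at hand gives a reason for the step from amino to cyclopropylamino.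

From the compounds shown here alone, whether the step belongs to the cyclopropyl ring itself or to any single carbon group on this nitrogen stays open, and methyl, ethyl or isopropyl in place of the amide hydrogen would separate the two readings, while cyclobutyl would show whether a larger ring carries the same step. Also open, going by these compounds, is what a methyl group in place of the remaining amide hydrogen of compound 4 would do in this assay.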